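Working notes: substituent changes on a shared core

A few compounds are considered here, and "the series" means these few. Any claim that something is new, unique, unknown or untested is made for them only; others in the source may bear on it.

Measured so far:
compound 1 `Nc1nc(-c2ccccc2F)cs1`: 6800 nM in a functional assay for agonist activity at thrombopoietin receptor (Homo sapiens); on this read-out higher numbers stand for an effect only at larger amounts of compound and lower numbers for an effect already at smaller amounts
compound 2 `Nc1nc(-c2c(F)cccc2F)cs1`: > 10000 nM in this assay (a limit)
compound 3 `Nc1nc(-c2cccc(OC(F)(F)F)c2F)cs1`: not yet measured in this assay

Going by the values given here, compound 1 gives the only numeric value shown in this assay. For compound 2 the value is a limit of the assay, not a number (the limit of > 10000 nM in this assay, at which 1 of the 2 values shown sits). The step of an at least 1.4-fold higher number from compound 1 to compound 2 (0.16 log units; that floor lies within the scatter) is therefore bounded only from below, and that floor lies within the scatter, so its size is not settled.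

Compound 3 differs from compound 1 by trifluoromethoxy in place of hydrogen on an aromatic carbon. Among the compounds with values here, the single measured step concerns a different group on the same ring, and because an at least 1.4-fold higher number from compound 1 to compound 2 (0.16 log units; that floor lies within the scatter) is only a floor it gives no firm size to carry over. Compound 3 is expected to change by about a 1.2-fold higher number from compound 1 to compound 3 (0.07 log units; within the scatter). Compound 3 is estimated at 8000 nM, with a range from 2500 nM to 25000 nM and a fair chance that only a limit is reported.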

Compound 3, half-maximal effective concentration: 32 nM
Estimate against measurement, compound 3: 250-fold (2.40 log units) above; measured number below the stated range.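

In this assay, trifluoromethoxy in place of hydrogen, on the aromatic carbon ortho to the fluoro group and meta to the 2-amino-1,3-thiazol-4-yl group, brings a 210-fold lower number from compound 1 to compound 3 (2.33 log units; beyond the scatter) and so lies far beyond the scatter. Going by these compounds alone, this carbon of the shared core therefore tolerates a substituent and can respond strongly to one, which the only earlier step, of unsettled size, could not show. No measured property among the data shown accounts for the size of this step.

On these data alone, whether the step belongs to trifluoromethoxy itself or would also appear with another group stays open, and methoxy, chloro, an amine or a carboxylic acid on this carbon would test that. Also open is what the fluoro group of compound 3 contributes to the step, since no compound shown carries trifluoromethoxy without it.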